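From Methylindole to Benzofuran: an Expected Small Step

The source may hold more compounds than are shown below. What is called first, only, known or untested is meant among the compounds shown, and "the series" means these compounds.

Compound 1 `O=C1OC(c2ccc3ccccc3n2)CN1C1CCN(Cc2cc3ccccc3[nH]2)CC1` in an in vitro functional assay on RBL cells for antagonist activity at C-C chemokine receptor type 8 (Homo sapiens), read by FLIPR and calcium flux; on this read-out higher numbers stand for weaker inhibition and lower numbers for stronger inhibition: compound 1 gives < 50200 nM, a limit of the assay rather than a number.
Compound 2 `COc1ccc2nccc(C3CN(C4CCN(Cc5cc6ccccc6n5C)CC4)C(=O)O3)c2c1` in this assay: compound 2 gives 3160 nM.

Going by the values given here, compound 2 holds the only true number in this set; compound 1 sits at the limit of < 50200 nM in this assay, at which 1 of the 2 values shown sits. Compound 3 `COc1ccc2nccc(C3CN(C4CCN(Cc5cc6ccccc6o5)CC4)C(=O)O3)c2c1` is not yet measured. It differs from compound 2 in one place: 1-benzofuran-2-yl in place of 1-methyl-1H-indol-2-yl on a saturated chain carbon bound to an amine nitrogen in a ring. Among the compounds with values here, no measured pair shows this swap, so the expectation rests on the change itself: a ring of the same shape with the oxygen replacing the methylated nitrogen. A small shift in this assay is expected, toward weaker inhibition if any, possibly none beyond the scatter. The expected step is a 1.6-fold higher number from compound 2 to compound 3 (0.20 log units; within the scatter). Compound 3 is estimated at 5000 nM, within 1500 nM to 16000 nM.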

Compound 3, half-maximal inhibitory concentration: 1260 nM
Estimate against measurement, compound 3: 4.0-fold (0.60 log units) above; the measured number lies below the stated range.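

On the saturated chain carbon bound to an amine nitrogen in a ring, 1-benzofuran-2-yl in place of 1-methyl-1H-indol-2-yl gives, in this assay, a 2.5-fold lower number from compound 2 to compound 3 (0.40 log units; beyond the scatter). Lower numbers stand for stronger inhibition, so this position accepts a ring oxygen in place of the methylated nitrogen, and the change moves toward stronger inhibition, something no earlier pair could show. Nothing measured here tells why the swap has this effect.

This single swap changes the ring atom and removes the methyl group together, and the compounds shown do not separate the two changes. Going by these compounds, whether 1-benzothiophen-2-yl, with sulfur as the ring atom, would give a similar number at this position remains open.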